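The source may report more compounds than this note shows. Statements on the series, on what has been measured and on what is new or still open speak of the compounds shown alone.

Measured compounds:
- compound 1, `CN(C)c1ccc(/C=C/C=C/C(=O)N2CCCCC2)cc1`, 13.4%
- compound 2, `COc1ccc(/C=C/C=C/C=C/C(=O)N2CCCCC2)cc1`, 1.08%
- compound 3, `COc1cc(OC)c(/C=C/C=C/C(=O)N2CCCCC2)c(OC)c1`, 77.1%

In an assay for inhibition of Polyunsaturated fatty acid 5-lipoxygenase (Homo sapiens), read by spectrophotometry, tested at 20 uM (on this read-out lower numbers stand for less inhibition and higher numbers for more inhibition at the one concentration tested (going by the name of the read-out)), compound 1 stands second highest of the three numbers. Its nearest neighbour is compound 2, which lies below it by a step beyond the scatter, while compound 3 lies far above it, also beyond the scatter. Compound 4, `O=C(/C=C/C=C/c1ccc(Cl)cc1)N1CCCCC1`, has not yet been measured in this assay. It differs from compound 1 in one place: chloro in place of dimethylamino on an aromatic carbon. For the measured compounds named here, no measured pair shows this change, so the shared core and chain of compound 1 are the only anchor. The step from compound 1 to compound 4 is expected to stay within the scatter, perhaps slightly downward. Compound 4 is therefore estimated at 11%, in the range 0% to 32%, which means an expected step of a number 2.4 percentage points lower from compound 1 to compound 4 (within the scatter).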

Compound 4, a percentage reported as inhibition, at one concentration (the size of the read-out at that concentration, not a potency): 14.5%
Estimate against measurement, compound 4: 3.5 percentage points below; low and high end bracket the measured number.
By their numbers in this assay, from the lowest: compound 2; then compounds 1 and 4 (each within the scatter of the next); then compound 3.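

For the compounds shown here, compound 4 gives the first pair in this assay that differs in one place, and the step is a number 1.1 percentage points higher from compound 1 to compound 4 (within the scatter) for chloro in place of dimethylamino on an aromatic carbon, para to a large group. At this position, exchanging the three heavy atoms and one hydrogen-bond acceptor of dimethylamino for a single chlorine atom does not separate the two compounds. Nothing on hand explains this result.

On these data alone, whether a carboxylic acid or a primary amine at this same place would also stay within the scatter of compound 1 remains open.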